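Cyclic amine on the amide nitrogen: compound 3 estimated

This account rests on a few compounds, and the source may have more. Where it says the series, first, only, none or still open, it means among the compounds named here.

Measured compounds:
compound 1 `O=C(NC1CCN(CC2CC2)C1)c1cc(-c2ccc(NS(=O)(=O)c3cccc(Cl)c3Cl)cc2)nc2[nH]ncc12` — 35 nM
compound 2 `CN(C)CCCNC(=O)c1cc(-c2ccc(NS(=O)(=O)c3cccc(Cl)c3Cl)cc2)nc2[nH]ncc12` — 633 nM

Two compounds share a core and differ only in the group on the amide-type nitrogen. In an assay for inhibition of serine/threonine-protein kinase Sgk1 (Homo sapiens), with stated times of 30 min and 60 min, in the presence of a further agent that is not named here (on this read-out higher numbers stand for weaker inhibition and lower numbers for stronger inhibition), compound 1 gives 35 nM, and compound 2 gives 633 nM. For the measured compounds named here, the step between them is an 18-fold higher number from compound 1 to compound 2 (1.26 log units; beyond the scatter), so compound 2 stands at the highest number of the two, with compound 1 as its only neighbour well apart from it.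

Compound 3 `CN1CC(NC(=O)c2cc(-c3ccc(NS(=O)(=O)c4cccc(Cl)c4Cl)cc3)nc3[nH]ncc23)C1` is not yet measured. Compared with compound 2 the change is 1-methylazetidin-3-yl in place of 3-(dimethylamino)propyl on an amide-type nitrogen whose other neighbour is the carbonyl carbon.

Going by the values given here, only one measured step bears on this: from compound 1 to compound 2 the number rose by an 18-fold higher number from compound 1 to compound 2 (1.26 log units; beyond the scatter) when 1-(cyclopropylmethyl)pyrrolidin-3-yl was replaced by the open chain. Compound 3 brings a ring back onto that nitrogen, though a different one, so the expectation is a move back toward compound 1, of the size a 5.8-fold lower number from compound 2 to compound 3 (0.76 log units; beyond the scatter), a lower number. Compound 3 is thus estimated at 110 nM in this assay, with a range from 30 nM to 400 nM.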

Compound 3, half-maximal inhibitory concentration: < 1 nM
Compound 3 gave a limit, no number; the forecaster's own chance of this, stated with the estimate: 2%; at least 110-fold (2.04 log units) between middle value and limit.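

The value for compound 3 in this assay is a limit of the assay and not a number: the limit of < 1 nM in this assay, at which 1 of the 3 values shown sits.

The step of an at least 630-fold lower number from compound 2 to compound 3 (2.80 log units; beyond the scatter) shows that the group on this amide-type nitrogen can shift the read-out much further than the first pair revealed, and this step is a minimum size, as the value it ends on is a limit. The step of an at least 35-fold lower number from compound 1 to compound 3 (1.54 log units; beyond the scatter) adds something compound 1 and compound 2 could not show: two cyclic amines on the same nitrogen stand apart beyond the scatter, so the presence of a ring there does not by itself set the level, and the identity of the ring and its substituent matters.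

The compounds shown leave open whether the difference between compound 1 and compound 3 follows the ring size or the group on the ring nitrogen, since the two change together; a 1-methylpyrrolidin-3-yl or a 1-(cyclopropylmethyl)azetidin-3-yl group on this nitrogen would separate them. They also leave open how an azetidin-3-yl group with a free ring amine would compare with the 1-methylazetidin-3-yl group of compound 3.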